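The source may report more compounds than this note shows. Statements on the series, on what has been measured and on what is new or still open speak of the compounds shown alone.

Of the compounds shown here, three built on one shared core have so far been tested in a functional assay on PC-3 cells (Homo sapiens) for antiproliferative activity, read by MTT assay; on this read-out lower numbers stand for stronger inhibition and higher numbers for weaker inhibition. Compound 1 `CNC(=O)c1ccc(Oc2cccc(NC(=S)Nc3ccc(C)c(C)c3)c2)nc1` gives 67400 nM, the highest number of the three and thus the weakest inhibition seen to date. Compound 2 `CNC(=O)c1ccc(Oc2cccc(NC(=S)Nc3ccc(F)c(C(F)(F)F)c3)c2)nc1` gives 7950 nM and compound 3 `CNC(=O)c1ccc(Oc2cccc(NC(=S)Nc3cc(C(F)(F)F)cc(C(F)(F)F)c3)c2)nc1` gives 5860 nM; both of these numbers lie well below that of compound 1, beyond the usual scatter, while the two of them lie within the scatter of each other. Compound 4 `CNC(=O)c1ccc(Oc2cccc(NC(=S)Nc3ccc(OC)cc3)c2)nc1` has not yet been measured. It differs from compound 1 in one place: 4-methoxyphenyl in place of 3,4-dimethylphenyl on an amide-type nitrogen whose other neighbour is the thiocarbonyl carbon. Among the measured compounds shown here, no measured pair tracks this particular exchange, so the expectation can rest only on compound 1 itself. The expected step is a 1.1-fold higher number from compound 1 to compound 4 (0.05 log units; within the scatter), which is to say none beyond the scatter, in either direction. Compound 4 is accordingly estimated at 75000 nM, with a range from 25000 nM to 220000 nM.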

Compound 4, half-maximal inhibitory concentration: > 100000 nM
Compound 4 ended at the assay's limit; the forecaster's own chance of this, stated with the estimate: 20%; middle value at least 1.3-fold (0.12 log units) from the limit.
By their numbers in this assay, from the lowest: compounds 3 and 2 (each within the scatter of the next); then compound 1. At a limit, above all of these: compound 4.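

In this assay compound 4 sits at a limit of the assay, > 100000 nM, and not at a number. Among the compounds shown here, this gives the first reading for an oxygen-bearing aryl group on this amide-type nitrogen: the exchange of 3,4-dimethylphenyl for 4-methoxyphenyl brings no gain in inhibition, and the step is an at least 1.4-fold higher number from compound 1 to compound 4 (0.17 log units; that floor lies within the scatter). Its floor stays within the scatter, so the true size of the step cannot be read, and a loss beyond the scatter is neither shown nor excluded, because the value is censored: the limit of > 100000 nM in this assay, at which 1 of the 4 values shown sits.

On these data alone, what remains open is how much of this outcome belongs to the methoxy group and how much to the loss of the second methyl group. As far as these compounds go, it is also open how an unsubstituted phenyl, or a phenyl carrying an amine or a carboxylic acid, would behave at this nitrogen.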